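Adding a second chloro to compound 2: expected effect on growth

This account rests on a few compounds, and the source may have more. Where it says the series, first, only, none or still open, it means among the compounds named here.

Measured so far:
compound 1 `O=C1NC(=S)/C(=C/c2ccc(Cl)cc2)S1` gives 3.91%
compound 2 `O=C1NC(=S)/C(=C/c2cccc(Cl)c2)S1` gives 5.44%
compound 3 `O=C1NC(=S)/C(=C/c2cccc(F)c2)S1` gives 7.03%

These three compounds share one core and differ only in the halogen on the aromatic ring and where it sits. In a functional assay on HEp-2 cells (Homo sapiens) for cytotoxicity, read by MTT assay, with a stated time of 72 h, tested at 2.5 ug/mL (on this read-out higher numbers stand for more inhibition of growth at the one concentration tested and lower numbers for less inhibition of growth), compound 2 gives 5.44%. Its nearest neighbour among the numbers is compound 1, and compound 3 is the furthest from it, yet both of these gaps lie within the usual scatter of repeated measurements, so the three values cannot be told apart. Among the measured compounds shown here, the one step between compounds that differ in a single place, a number 1.6 percentage points higher from compound 2 to compound 3 (within the scatter), confirms this: swapping the halogen changed nothing that can be trusted.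

Compound 4 `O=C1NC(=S)/C(=C/c2ccc(Cl)c(Cl)c2)S1` is not yet measured. It differs from compound 2 by chloro in place of hydrogen on an aromatic carbon; the new chloro sits ortho to a chloro group and para to a group of 8 heavy atoms. For the measured compounds named here, no measured step adds a group to the ring, so nothing bears directly on this change. Going by the values given here, the only step on record is within the scatter, and all three values are small.

Compound 4 is therefore expected to show a step of a number 1.6 percentage points higher from compound 2 to compound 4 (within the scatter) in this assay, that is, none beyond the scatter. The estimate for compound 4 is 7%, with a range from 0% to 22%.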

Compound 4, percent growth inhibition at one concentration: 5.03%
Compound 4: middle estimate off by 2 percentage points, on the high side; measured number inside the range.
By their numbers in this assay, from the lowest: compounds 1, 4, 2 and 3 (each within the scatter of the next).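

Among the compounds shown here, compound 4 is the first case here in which a group is added to the ring rather than one halogen being swapped for another: in this assay, a new chloro ortho to a chloro group and para to a group of 8 heavy atoms gives a number 0.4 percentage points lower from compound 2 to compound 4 (within the scatter), and the same compound, seen as compound 1 with one more chloro, gives a number 1.1 percentage points higher from compound 1 to compound 4 (within the scatter). Both steps therefore show that, for this pair of changes, a second chloro on the ring does not shift growth inhibition by more than repeated measurements of this kind would vary, so adding a halogen has so far proved as uneventful as exchanging one. Nothing measured alongside these numbers accounts for this lack of change.

All of the ring changes shown involve chloro or fluoro, so it remains open whether a different kind of group at this position, such as an amine, a carboxylic acid or a longer chain, would produce a step beyond the scatter. The compounds shown also leave open how the shared core behaves when something other than the aromatic ring is changed, for instance when the thiocarbonyl sulfur is replaced by oxygen.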